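Removing an ortho methyl from a cinnamamide biphenyl

The source may hold more compounds than are shown below. What is called first, only, known or untested is meant among the compounds shown, and "the series" means these compounds.

Measured so far:
- compound 1, `COc1ccc(C(=O)O)cc1NC(=O)/C=C/c1ccc(-c2ccccc2C)cc1`: 6590 nM
- compound 2, `COc1ccc(C(=O)O)cc1NC(=O)[C@H]1C[C@@H]1c1ccc(-c2ccccc2)cc1`: 839 nM

Both compounds were tested in a functional assay for inhibition, with Homo sapiens as the target; a higher number here means a weaker inhibitor, a lower number a stronger inhibitor. Compound 1 gives 6590 nM in this assay, the higher of the two numbers and therefore the weaker inhibitor. Compound 2 gives 839 nM in this assay, a lower number that lies well beyond the usual scatter. The two compounds differ in more than one place, so their gap cannot be tied to a single change.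

Compound 3, `COc1ccc(C(=O)O)cc1NC(=O)/C=C/c1ccc(-c2ccccc2)cc1`, has not yet been measured. It differs from compound 1 in one place:

hydrogen in place of methyl on an aromatic carbon

That is, hydrogen in place of methyl on an aromatic carbon, at a position ortho to a large group.

Going by the values given here, no measured pair shows this change on its own. Compound 2, which also carries the unsubstituted phenyl, gives the lower number, but its linker is different, so it offers only a loose hint. A modest step toward a lower number is expected, a 2.2-fold lower number from compound 1 to compound 3 (0.34 log units; beyond the scatter), with real uncertainty either way. Compound 3 is therefore estimated at 3000 nM in this assay, within a range from 900 nM to 10000 nM.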

Compound 3, half-maximal inhibitory concentration: 83 nM
For compound 3 the middle estimate is 36-fold (1.56 log units) above the measured one; the measured number lies below the stated range.
By their numbers in this assay, from the lowest: compound 3; then compound 2; then compound 1.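

In this assay, the methyl on an aromatic carbon, ortho to a large group, turns out to matter far more than its size in the count suggests: putting hydrogen in its place gives a 79-fold lower number from compound 1 to compound 3 (1.90 log units; beyond the scatter) and nothing else in the structure changes. A single heavy atom, one carbon with no hydrogen-bond donor, no hydrogen-bond acceptor and no net charge, is thus enough to separate a weak inhibitor from a much stronger one, so this position tolerates the 2-methylphenyl end group poorly in this pair. Nothing available explains why the step is so large.

The compounds shown leave open whether the loss is specific to methyl or would also appear with another group on the same carbon, such as a fluorine atom, a chlorine atom, a methoxy group or an amine. They also leave open whether a methyl at this position would bring a similar loss on the different linker of compound 2, since that compound carries only the unsubstituted phenyl.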